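Trimming one methyl from the lactam ring

The source may hold more compounds than are shown below. What is called first, only, known or untested is meant among the compounds shown, and "the series" means these compounds.

Compound 1 `Fc1ccc2c(c1CNc1ncc(Oc3ccccc3)c3nncn13)CCO2` gives 3.5 in a physicochemical assay for lipophilicity, using the shake flask method, in phosphate buffer, measured as octanol-water partition, with a stated time of 30 min, at pH 7.4; on this read-out higher numbers stand for higher lipophilicity and lower numbers for lower lipophilicity. Compound 2 `CC1(C)CC(=O)N(c2cnc(NCc3c(F)ccc4c3CCO4)n3cnnc23)C1` gives 2 in this assay, after a change of 4,4-dimethyl-2-oxopyrrolidin-1-yl in place of phenoxy on an aromatic carbon, which is a number 1.50 log units lower from compound 1 to compound 2 (beyond the scatter). For the measured compounds named here, of the two numbers in hand, compound 2 stands lowest, with compound 1 as its only neighbour at the higher end.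

Compound 3 `C[C@@H]1CC(=O)N(c2cnc(NCc3c(F)ccc4c3CCO4)n3cnnc23)C1` carries the following difference from compound 2:
4-methyl-2-oxopyrrolidin-1-yl in place of 4,4-dimethyl-2-oxopyrrolidin-1-yl on an aromatic carbon
Going by the values given here, the only measured step concerns the replacement of phenoxy by the whole lactam ring and is large; it does not bear directly on the removal of one methyl from a ring that is otherwise kept. The change from compound 2 to compound 3 removes one carbon, a far smaller alteration than the measured one, so a small step downward, near the edge of the scatter, is expected in this assay. The expected step is a number 0.30 log units lower from compound 2 to compound 3 (within the scatter). The estimate for compound 3 is 1.7, with a range from 1.3 to 2.1.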

Compound 3, distribution coefficient: 1.8
Compound 3: middle estimate off by 0.10 log units, on the low side, and the stated range covers the measured number.
By their numbers in this assay, from the lowest: compounds 3 and 2 (each within the scatter of the next); then compound 1.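

In this assay the lactam at this aromatic carbon keeps nearly the same number when it loses one methyl: 4-methyl-2-oxopyrrolidin-1-yl in place of 4,4-dimethyl-2-oxopyrrolidin-1-yl gives a number 0.20 log units lower from compound 2 to compound 3 (within the scatter) and so the two lactams cannot be told apart on this read-out. The large gap to the phenoxy compound remains with the single methyl, since 4-methyl-2-oxopyrrolidin-1-yl in place of phenoxy gives a number 1.70 log units lower from compound 1 to compound 3 (beyond the scatter) and this shows that the drop seen earlier does not depend on the second methyl being present. No supporting measurement in hand accounts for either step.

The compounds shown leave open how the number would respond to a lactam ring with no methyl at all, to the mirror-image form of the 4-methyl group, or to a longer chain such as a 4-propyl group on the same ring. They also leave open whether a quite different group on this aromatic carbon, such as a morpholine ring, an open-chain amide or a carboxylic acid, would fall near the two lactams or near phenoxy.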